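This account rests on a few compounds, and the source may have more. Where it says the series, first, only, none or still open, it means among the compounds named here.

Compound 1 `O=C(NCCCNc1cc(-c2cn(-c3ccccc3)nc2-c2cccc(O)c2)ccn1)Nc1ccc(F)cc1`: 2790 nM
Compound 2 `O=C(NCCCNc1cc(-c2cn(-c3ccccc3)nc2-c2cccc(O)c2)ccn1)Nc1cccc(C(F)(F)F)c1`: 3650 nM
Compound 3 `COc1cccc(-c2nn(-c3ccccc3)cc2-c2ccnc(NCCCNC(=O)Nc3ccc(F)cc3)c2)c1`: not yet measured

Going by the values given here, in a functional assay on SN12C cells (Homo sapiens) for antiproliferative activity, read by sulforhodamine B assay, with a stated time of 48 h (a higher number here means a weaker inhibitor, a lower number a stronger inhibitor), compound 1 gives 2790 nM, and the only measured step is a 1.3-fold higher number from compound 1 to compound 2 (0.12 log units; within the scatter), so the two stand level. Compound 3 carries one change: methyl in place of hydrogen on an oxygen on an aromatic ring, that is, hydroxy to methoxy. The measured step lies on an amide-type nitrogen, not on this oxygen, so no data speak directly to the change. No direction is supported, and no shift beyond the scatter is expected in this assay. The expected step is a 1.1-fold higher number from compound 1 to compound 3 (0.06 log units; within the scatter). The expected value for compound 3 is 3200 nM, within an estimated range of 1300 nM to 8000 nM.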

Compound 3, half-maximal inhibitory concentration: 9830 nM
Compound 3: middle estimate off by 3.1-fold (0.49 log units), on the low side; the whole stated range lies below it.
By their numbers in this assay, from the lowest: compounds 1 and 2 (each within the scatter of the next); then compound 3.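

In this assay, the change from hydroxy to methoxy gives a 3.5-fold higher number from compound 1 to compound 3 (0.55 log units; beyond the scatter). Going by these compounds alone, this is the first step beyond the scatter, and it shows that this oxygen on the aromatic ring is sensitive to substitution, which a 1.3-fold higher number from compound 1 to compound 2 (0.12 log units; within the scatter) on the amide-type nitrogen could not show. Nothing measured here accounts for the step.

From the compounds shown here alone, whether an amine or an ethoxy group in place of the hydroxy would keep the number of compound 1 remains open. Also open, going by these compounds, is whether the methoxy step repeats with 3-(trifluoromethyl)phenyl on the amide-type nitrogen.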